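The compounds below may be only part of what the source reports. "The series", "measured", "known", "first", "only" and "open" are said of these compounds alone.

For the measured compounds named here, compound 1 `Cc1ccc(N2C(=O)N/C(=C\c3ccc(O)cc3)C2=O)cc1` is the only member of the series with a numerical value in a functional assay on NCI-H292 cells (Homo sapiens) for antiproliferative activity; on this read-out lower numbers stand for stronger inhibition and higher numbers for weaker inhibition; in this assay compound 1 gives 27900 nM. Compound 2 `O=C1N/C(=C\c2ccc(O)cc2)C(=O)N1c1cccc(I)c1` is recorded in this assay only at a limit, > 200000 nM. Going by the values given here, the single step joining measured compounds, an at least 7.1-fold higher number from compound 1 to compound 2 (0.85 log units; beyond the scatter), runs up to the limit of > 200000 nM in this assay, at which 1 of the 2 values shown sits, so its true size is not known beyond that. Compound 3 `O=C(NCc1ccccc1)c1ccc(N2C(=O)N/C(=C\c3ccc(O)cc3)C2=O)cc1` differs from compound 1 by benzylcarbamoyl in place of methyl on an aromatic carbon. Among the compounds with values here, that measured step exchanged the whole aryl group on the ring nitrogen of the shared core, whereas the change to compound 3 keeps the aryl group and extends it from the aromatic carbon named above; no measured pair tests such an extension, so the data give no direction for it. The expectation for compound 3 in this assay is therefore a step of about a 1.1-fold lower number from compound 1 to compound 3 (0.05 log units; within the scatter), within the scatter, with a wide range. Compound 3 is estimated at 25000 nM, between 6000 nM and 100000 nM.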

Compound 3, half-maximal inhibitory concentration: > 200000 nM
Compound 3: a limit, no number; the forecaster's own chance of this, stated with the estimate: 15%; at least 8.0-fold (0.90 log units) between middle value and limit.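

Benzylcarbamoyl in place of methyl on the aromatic carbon gives an at least 7.1-fold higher number from compound 1 to compound 3 (0.85 log units; beyond the scatter) in this assay, so a change that keeps the aryl group and extends it from this carbon also moves beyond the scatter. For the compounds shown here, compound 1 remains the only compound with a number, as neither the 3-iodophenyl exchange nor the benzylcarbamoyl extension leaves a numerical value. Compound 3 is recorded only at a limit, and the true size of its step stays unknown because of that: the limit of > 200000 nM in this assay, at which 2 of the 3 values shown sit.

The compounds shown do not separate the amide link from the added aromatic ring as the part tied to the loss. From the compounds shown here alone, it also stays open whether a smaller group on the same carbon, such as a primary carboxamide or a carboxylic acid, would match or improve on compound 1 at 27900 nM.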